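Replacing the cyanomethyl group on the shared core

The source may report more compounds than this note shows. Statements on the series, on what has been measured and on what is new or still open speak of the compounds shown alone.

Measured so far in a functional assay on the whole organism with Rattus norvegicus as the target, with a stated time of 4 h, at a dose of 40 mg/kg by the intraperitoneal route; a lower number here means less inhibition, a higher number more inhibition at the dose given (going by the name of the read-out):
compound 1 `Cc1nc2c(OCc3ccccc3)cccn2c1CCC#N` gives 40%
compound 2 `Cc1nc2c(OCc3ccccc3)cccn2c1CO` gives 99%
compound 3 `CCOCc1c(C)nc2c(OCc3ccccc3)cccn12` gives 84%

Compound 1 stands lowest of the three numbers in this assay; its nearest neighbour is compound 3 and its furthest is compound 2, and both gaps lie beyond the scatter. Two steps out of compound 1 are known: a number 59 percentage points higher from compound 1 to compound 2 (beyond the scatter) and a number 44 percentage points higher from compound 1 to compound 3 (beyond the scatter). Between the two groups that replaced the cyanomethyl, a number 15 percentage points lower from compound 2 to compound 3 (beyond the scatter).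

Compound 4 `Cc1nc2c(OCc3ccccc3)cccn2c1CC1=NCCN1` has not yet been measured. It differs from compound 1 in one place: a group of 5 heavy atoms (3 carbon, 2 nitrogen; one five-membered non-aromatic ring with 2 hetero atoms) in place of a group of 3 heavy atoms (2 carbon, 1 nitrogen; no ring), on a saturated chain carbon bound to an aromatic carbon. Both recorded replacements of the cyanomethyl group on that saturated chain carbon raised inhibition in this assay by a large margin, so the step from compound 1 to compound 4 is expected to go upward as well. Among the measured compounds shown here, the group entering here is of another kind than a hydroxy or an ethoxy group, carrying a five-membered non-aromatic ring with a hydrogen-bond donor and two acceptors, and no measured step covers such a change, so the size is expected with a wide range. The estimate for compound 4 in this assay is 70%, within 35% to 95%, an expected step of a number 30 percentage points higher from compound 1 to compound 4 (beyond the scatter).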

Compound 4, a percentage reported as inhibition, in the whole organism at one dose (the size of the read-out at that dose, not a potency): 69%
The estimate for compound 4 lay 1 percentage points above the measured number; measured number inside the range.
By their numbers in this assay, from the lowest: compound 1; then compound 4; then compound 3; then compound 2.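

In this assay, the group with one five-membered non-aromatic ring with 2 hetero atoms also beats cyanomethyl on the saturated chain carbon bound to an aromatic carbon (a number 29 percentage points higher from compound 1 to compound 4 (beyond the scatter)), so a ring-bearing group with a hydrogen-bond donor joins hydroxy and ethoxy in moving the number upward; among the listed compounds, no replacement of cyanomethyl goes against this direction. The new group nevertheless falls short of both oxygen-linked replacements (a number 15 percentage points lower from compound 3 to compound 4 (beyond the scatter); a number 30 percentage points lower from compound 2 to compound 4 (beyond the scatter)), which places compound 4 in the middle of the series, above compound 1 and below compound 3 and compound 2. No measurement is available to explain either the rise from compound 1 or the shortfall from the two oxygen-linked compounds.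

The compounds shown leave open whether the ring itself matters, a question that an open-chain amidine on the same saturated chain carbon would address. Among the compounds shown here, they also leave open how a primary amine, a carboxylic acid or a longer chain ending in the same five-membered ring would compare with hydroxy, the replacement with the highest number so far.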